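The compounds below may be only part of what the source reports. "The series", "measured", "known", "first", "only" and "open" are said of these compounds alone.

Measured in a functional assay on MDA-MB-231 cells (Homo sapiens) for antiproliferative activity, read by MTT assay; on this read-out higher numbers stand for weaker inhibition and lower numbers for stronger inhibition:
- compound 1 `CCCCC/C=C\C/C=C\CCCCCCCc1cc(=O)c2c(O)c(C)c(O)cc2o1`: 16100 nM
- compound 2 `CCCC/C=C\CCCCCCCCCc1cc(=O)c2c(O)cc(O)cc2o1`: 6790 nM

Going by the values given here, with only two measured compounds, the series offers little to work from. Compound 2 has the lower number of the pair, and the gap to compound 1 lies beyond the scatter. Among the compounds with values here, no measured pair differs in one place only, so no single change has a measured size yet.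

The next compound is compound 3 `CCCC/C=C\CCCCCCCCCc1cc(=O)c2c(O)c(C)c(O)cc2o1`, which differs from compound 2 by one change: methyl in place of hydrogen on an aromatic carbon. Compound 1 also carries this methyl, on a different chain, and gives 16100 nM. That value hints at weaker inhibition with the methyl, but the chain differs as well, so the methyl cannot be separated from it.

A small rise in the number is therefore expected in this assay, within the scatter: the estimated change is a 1.5-fold higher number from compound 2 to compound 3 (0.17 log units; within the scatter). The expected value for compound 3 is 10000 nM, with an estimated range of 4000 nM to 25000 nM.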

Compound 3, half-maximal inhibitory concentration: 42800 nM
Estimate against measurement, compound 3: 4.3-fold (0.63 log units) below, outside the stated range (above it).
By their numbers in this assay, from the lowest: compound 2; then compound 1; then compound 3.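

In this assay, methyl in place of hydrogen on the aromatic carbon ortho to two hydroxy groups gives a 6.3-fold higher number from compound 2 to compound 3 (0.80 log units; beyond the scatter), the first measured size for this change with the chain held constant. Inhibition weakens beyond the scatter with the entry of just one heavy atom, so this position is sensitive to substitution, at least in the context of this chain. With the methyl held constant, oct-3-en-1-yl in place of deca-1,4-dien-1-yl gives a 2.7-fold higher number from compound 1 to compound 3 (0.42 log units; beyond the scatter), which shows that the chain also shifts the number beyond the scatter and that the methyl and the chain each have a measurable part in the values of the methylated compounds.

As far as these compounds go, whether the methyl step carries over to the deca-1,4-dien-1-yl chain remains open, as does what an ethyl group, a chlorine atom or a methoxy group on this same aromatic carbon would give. No measurement at hand accounts for the size of either step.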